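Thiazolidinone amides: aryl swap on the ring nitrogen

The source may report more compounds than this note shows. Statements on the series, on what has been measured and on what is new or still open speak of the compounds shown alone.

Measured so far:
compound 1 `COc1ccccc1N1C(=O)C(C)SC1c1cccc(C(=O)NCCCCc2ccccc2)c1` — 45.1 nM
compound 2 `COc1ccccc1N1C(=O)CSC1c1cccc(C(=O)NCCCCc2ccc(Cl)cc2)c1` — 78.6 nM
compound 3 `O=C(NCCCCc1ccccc1)c1cccc(C2SCC(=O)N2c2ccc(-c3ccccc3)cc2)c1` — > 1000 nM

In a functional assay on HOS-TE85 cells (Homo sapiens) for inhibition, read by CCK-8 assay, with a stated time of 72 h (on this read-out higher numbers stand for weaker inhibition and lower numbers for stronger inhibition), compound 1 gives 45.1 nM and compound 2 gives 78.6 nM; both carry a 2-methoxyphenyl on the ring nitrogen of the shared core, and these two values lie within the scatter of each other. Compound 3, which instead bears a 4-phenylphenyl there, reports only a limit in this assay, > 1000 nM, so it stands at the weak end of the three numbers shown and no exact value is known for it (the limit of > 1000 nM in this assay, at which 1 of the 3 values shown sits).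

Compound 4 `COc1cccc(OC)c1N1C(=O)CSC1c1cccc(C(=O)NCCCCc2ccccc2)c1` is not yet measured. It differs from compound 3 by 2,6-dimethoxyphenyl in place of 4-phenylphenyl on an amide-type nitrogen in a ring. For the measured compounds named here, no measured step is available for this pair. The change moves the substituent back toward the methoxy-bearing pattern of compound 1 and compound 2, so a return toward their range is expected; how far is uncertain. Compound 4 is estimated at 150 nM in this assay, with a likely range of 40 nM to 600 nM, meaning an expected step of an at least 6.6-fold lower number from compound 3 to compound 4 (0.82 log units; beyond the scatter).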

Compound 4, half-maximal inhibitory concentration: > 1000 nM
Compound 4 gave a limit, no number; the forecaster's own chance of this, stated with the estimate: 15%; middle value at least 6.6-fold (0.82 log units) away from the limit.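

In this assay, for the compounds shown here, compound 3 and compound 4 both report only a limit, so no step between them can be read: the limit of > 1000 nM in this assay, at which 2 of the 4 values shown sit. Still open, going by these compounds, is how 2-methoxyphenyl compares with 2,6-dimethoxyphenyl or 4-phenylphenyl on an otherwise identical compound.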